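From tert-butyl to ethyl on the shared core

This account rests on a few compounds, and the source may have more. Where it says the series, first, only, none or still open, it means among the compounds named here.

Compound 1 `CC(C)(C)[C@]1(c2ccccc2)OCC[C@H](CCNCc2ccccc2)O1` gives 253 nM in an assay on brain for displacement of a labelled ligand from Sigma non-opioid intracellular receptor 1 (Cavia porcellus); a higher number here means a weaker inhibitor, a lower number a stronger inhibitor. Among the two numbers in hand it is the highest, and its nearest neighbour is compound 3 `CC(C)(C)[C@@]1(c2ccccc2)OCC[C@@H](CCNCc2ccccc2)O1`, which gives 128 nM; the step of a 2.0-fold lower number from compound 1 to compound 3 (0.30 log units; within the scatter) is small, and the two compounds differ only in configuration (the fact that compounds 1 and 3 differ only in the configuration as drawn). Compound 2 `CC(C)(C)[C@]1(c2ccccc2)OCC[C@H](CCN)O1` reaches only the limit of > 10000 nM in this assay. The step of an at least 39-fold higher number from compound 1 to compound 2 (1.59 log units; beyond the scatter) is large, resting on (the limit of > 10000 nM in this assay, at which 1 of the 3 values shown sits).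

Compound 4 `CC[C@]1(c2ccccc2)OCC[C@H](CCNCc2ccccc2)O1` differs from compound 1 by ethyl in place of tert-butyl on a saturated ring carbon. Neither measured step touches this position: the step from compound 1 to compound 2 concerns the amine nitrogen, and the step from compound 1 to compound 3 changes no group. The measured steps give no guide to the direction of this change, so only a modest shift is expected, with the number more likely to rise than to fall. Compound 4 is therefore estimated to give 450 nM, in a range from 120 nM to 1800 nM. That estimate means an expected step of a 1.8-fold higher number from compound 1 to compound 4 (0.25 log units; within the scatter).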

Compound 4, inhibition constant: 28 nM
Estimate against measurement, compound 4: 16-fold (1.21 log units) above, and the stated range ends above it.
By their numbers in this assay, from the lowest: compound 4; then compounds 3 and 1 (each within the scatter of the next). At a limit, above all of these: compound 2.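

Replacing tert-butyl with ethyl on the saturated ring carbon between two ring oxygen atoms gives a 9.0-fold lower number from compound 1 to compound 4 (0.96 log units; beyond the scatter) in this assay. Until now, only the change on the amine nitrogen had given a step beyond the scatter, so this ring carbon is a second place where the group clearly moves the number, here downward with ethyl, which has 2 heavy atoms against 4 in tert-butyl. Nothing measured in the compounds shown accounts for this step.

On these data alone, it remains open whether the number would keep falling with methyl at this position or rise again with a longer chain such as n-propyl. Also open, as far as these compounds go, is whether the mirror image of compound 4 would give a value as close to compound 4 as compound 3 gives to compound 1.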